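Bromo for hydrogen on the aryl ring of compound 1

This account rests on a few compounds, and the source may have more. Where it says the series, first, only, none or still open, it means among the compounds named here.

Compound 1 `O=C1N/C(=N/c2ccccc2)S/C1=C\c1ccccn1`: 29.2%
Compound 2 `O=C1N/C(=N\Nc2ccccc2)S/C1=C\c1ccccn1`: 46.2%

Of the compounds shown here, two have been measured in a functional assay on the whole organism (strain Swiss albino) for inhibition, with Mus musculus as the target, in the writhing test, with stated times of 30 min and 15 min, at a dose of 50 mg/kg by the oral route; on this read-out lower numbers stand for less inhibition and higher numbers for more inhibition at the one dose given (going by the name of the read-out). Compound 1 `O=C1N/C(=N/c2ccccc2)S/C1=C\c1ccccn1` gives 29.2% in this assay, the lower of the two numbers. Compound 2 `O=C1N/C(=N\Nc2ccccc2)S/C1=C\c1ccccn1` gives 46.2%, a number that lies above the usual scatter of compound 1; no single-point change links the two, so their values are simply set side by side.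

The step followed here leads from compound 1 to compound 3 `O=C1N/C(=N/c2ccc(Br)cc2)S/C1=C\c1ccccn1`, which has not yet been measured in this assay. The change is bromo in place of hydrogen on an aromatic carbon. Going by the values given here, nothing among the measured compounds shows how such an exchange on that ring moves the read-out, since compound 2 differs from compound 1 in another place. The expectation for the step from compound 1 to compound 3 is therefore a small one, a number 3.8 percentage points higher from compound 1 to compound 3 (within the scatter), not clearly beyond the scatter in either direction. Compound 3 is expected to give about 33% in this assay, with a range from 18% to 48%.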

Compound 3, a percentage reported as inhibition, in the whole organism at one dose (the size of the read-out at that dose, not a potency): 28.7%
Beside the measured number, compound 3's estimate is 4.3 percentage points above it; low and high end bracket the measured number.
By their numbers in this assay, from the lowest: compounds 3 and 1 (each within the scatter of the next); then compound 2.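

In this assay, bromo in place of hydrogen on an aromatic carbon, para to a large group, gives a number 0.5 percentage points lower from compound 1 to compound 3 (within the scatter) and so leaves the read-out of compound 1 where it was. Going by these compounds alone, this is the first step that changes only one place, and it shows that the phenyl to 4-bromophenyl exchange at this position, with one heavy atom added and no hydrogen-bond donor or acceptor, makes no difference beyond the scatter at the one dose tested, which the side-by-side values of the earlier compounds could not show. No measurement shown bears on why the read-out stays the same, and the single step cannot say whether this position matters for the read-out in general.

The compounds shown leave open whether a different group at the same place, such as an amine, a carboxylic acid, a methoxy group or a longer alkyl chain, would also leave the read-out unchanged. They also leave open whether bromo elsewhere on this ring, or on the aryl ring of compound 2, would give the same result.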